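Working notes on cytotoxicity across a shared-core series

The source may report more compounds than this note shows. Statements on the series, on what has been measured and on what is new or still open speak of the compounds shown alone.

Measured so far:
Compound 1 `CNC(=O)c1cc(Oc2ccc(NC(=O)c3nn(-c4ccc(Br)cc4F)c(=O)cc3C)cc2F)ccn1`; in a functional assay on HepG2 cells (Homo sapiens) for cytotoxicity, read by MTT assay, with a stated time of 72 h (on this read-out lower numbers stand for stronger inhibition and higher numbers for weaker inhibition), compound 1 gives 2830 nM.
Compound 2 `CNC(=O)c1cc(Oc2ccc(NC(=O)c3nn(-c4ccccc4OC(F)(F)F)c(=O)cc3C)cc2F)ccn1`; in this assay compound 2 reaches only a limit of the assay, > 40000 nM.
Compound 3 `Cc1cc(=O)n(-c2ccc(Br)cc2F)nc1C(=O)Nc1ccc(Oc2ncnc3sccc23)cc1`; in this assay compound 3 gives 6300 nM.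

Compound 3 stands highest of the two plain numbers, with compound 1 nearest. The difference between the core of compound 1 and the core of compound 3 is not broken down here.

From compound 1 to compound 2 the change is 2-(trifluoromethoxy)phenyl in place of 4-bromo-2-fluorophenyl on an aromatic nitrogen, and it made an at least 14-fold higher number from compound 1 to compound 2 (1.15 log units; beyond the scatter); the value of compound 2 sits at a limit, as shown by the limit of > 40000 nM in this assay, at which 1 of the 3 values shown sits.

Compound 4 `Cc1cc(=O)n(-c2ccccc2OC(F)(F)F)nc1C(=O)Nc1ccc(Oc2ncnc3sccc23)cc1` is not yet measured. It differs from compound 3 by 2-(trifluoromethoxy)phenyl in place of 4-bromo-2-fluorophenyl on an aromatic nitrogen, the same change at the same place. Among the compounds with values here, the step expected from compound 3 to compound 4 in this assay is an 11-fold higher number from compound 3 to compound 4 (1.05 log units; beyond the scatter), resting on the single measured step of an at least 14-fold higher number from compound 1 to compound 2 (1.15 log units; beyond the scatter) and on the starting value of compound 3, 6300 nM. Compound 4 is accordingly estimated at 70000 nM, with a range from 20000 nM to 300000 nM, and a limit rather than a number is the likelier outcome.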

Compound 4, half-maximal inhibitory concentration: 14400 nM
For compound 4 the middle estimate is 4.9-fold (0.69 log units) above the measured one; the measured number lies below the stated range.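

In this assay, 2-(trifluoromethoxy)phenyl in place of 4-bromo-2-fluorophenyl on the aromatic nitrogen again gives a higher number, with a 2.3-fold higher number from compound 3 to compound 4 (0.36 log units; beyond the scatter), so the direction of the change carries from the core of compound 1 to the core of compound 3. The size of the change does not carry over, and the two steps differ: the same change on two cores in this assay, an at least 14-fold higher number (1.15 log units; beyond the scatter) from compound 1 to compound 2 and a 2.3-fold higher number (0.36 log units; beyond the scatter) from compound 3 to compound 4, at least 6.1-fold (0.79 log units) apart, beyond the scatter of two such steps Compound 2 is at a limit and does not give a plain number, so the full size of its step remains unknown, and the data show neither the reason for the gap nor a rule for other cores: the limit of > 40000 nM in this assay, at which 1 of the 4 values shown sits.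

The compounds shown leave open how an unsubstituted phenyl, or a phenyl carrying an amine or a carboxylic acid, would behave at this nitrogen on either core. It also remains open whether the same direction would hold on a third core, since only two cores are shown here.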